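Compound 3 and its 2,4-dichlorophenyl isomer, compound 4

The source may hold more compounds than are shown below. What is called first, only, known or untested is meant among the compounds shown, and "the series" means these compounds.

Readings in an ADME assay on HEK-293T cells (Homo sapiens) for cytotoxicity, read by CCK-8 assay, with a stated time of 48 h; a lower number here means that less compound is tolerated, a higher number that more compound is tolerated:
compound 1 `CCOc1ccccc1NC(=O)CSc1c[nH]c2c(Cl)cccc12` gives > 100000 nM, a limit of the assay.
compound 2 `O=C(CSc1c[nH]c2ccc(Cl)cc12)Nc1ccc(Cl)c(Cl)c1` gives 42700 nM.
compound 3 `Cn1cc(S(=O)(=O)CC(=O)Nc2cc(Cl)ccc2Cl)c2ccccc21` gives > 100000 nM, again a limit of the assay.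

Compound 3 therefore stands not at a number but at the limit of > 100000 nM in this assay, at which 2 of the 3 values shown sit. Compound 4 `Cn1cc(S(=O)(=O)CC(=O)Nc2ccc(Cl)cc2Cl)c2ccccc21` has not been measured. It differs from compound 3 in one place: 2,4-dichlorophenyl in place of 2,5-dichlorophenyl on an amide-type nitrogen. Among the measured compounds shown here, with no measured step of this kind at hand, the expected step is none beyond the usual scatter, so the estimated step is a number no higher from compound 3 to compound 4 (the limit leaves the size open), most likely ending as a limit once more. Compound 4 is accordingly expected to give about 100000 nM, within a range from 50000 nM to 200000 nM.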

Compound 4, half-maximal cytotoxic concentration: > 100000 nM
Compound 4: a limit, no number (the forecaster's own chance of this, stated with the estimate: 70%); the middle value lies on the limit itself.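

Compound 3 and compound 4 both stand at a limit, so no step can be read between them: the limit of > 100000 nM in this assay, at which 3 of the 4 values shown sit.

The compounds shown leave open whether 2,4-dichlorophenyl and 2,5-dichlorophenyl on an amide-type nitrogen differ at all in how much compound is tolerated.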